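Iodo in place of a basic side chain on the shared core

This account rests on a few compounds, and the source may have more. Where it says the series, first, only, none or still open, it means among the compounds named here.

Measured so far:
compound 1 `COc1ccc2c(CN(C)C)cn(CCNC(C)=O)c2n1`: > 10000 nM
compound 2 `COc1ccc2c(CN3CCC(C(=O)c4ccc(F)cc4)CC3)cn(CCNC(C)=O)c2n1`: 9490 nM

Both values come from an assay on HEK293 cells for displacement of a labelled ligand from melatonin receptor type 1A (Homo sapiens); on this read-out lower numbers stand for stronger inhibition and higher numbers for weaker inhibition. For compound 1 the value > 10000 nM is a limit of the assay, not a number, and the limit of > 10000 nM in this assay, at which 1 of the 2 values shown sits, tells where it sits. In this assay compound 2 gives 9490 nM. Among the measured compounds shown here, no step between measured compounds is available, so the two values only show that both compounds are weak.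

Compound 3 `COc1ccc2c(I)cn(CCNC(C)=O)c2n1` has not yet been measured. It differs from compound 1 in one place: iodo in place of (dimethylamino)methyl on an aromatic carbon. For the measured compounds named here, with no measured step to lean on, the size of the change cannot be read from the data. The expectation is that compound 3 stays weak, with a step of an at least 1.6-fold lower number from compound 1 to compound 3 (0.22 log units; that floor lies within the scatter) that may still be within the scatter. The estimate for compound 3 in this assay is 6000 nM, with a range from 800 nM to 30000 nM.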

Compound 3, inhibition constant: 16 nM
Compound 3: the middle estimate sits 380-fold (2.57 log units) above what was measured; measured number outside the range, below it.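

In this assay, the aromatic carbon of the five-membered ring turns out not to be a place where the shared core must stay weak: iodo in place of (dimethylamino)methyl gives an at least 620-fold lower number from compound 1 to compound 3 (2.79 log units; beyond the scatter). Among the compounds shown here, compound 1 and compound 2 both carry an amine side chain here and both read weak, so only this step shows that the group on this carbon can decide the result. Compound 1 gives > 10000 nM, which is a limit of the assay and not a number, so the full size of the step cannot be read: the limit of > 10000 nM in this assay, at which 1 of the 3 values shown sits.

From the compounds shown here alone, what stays open is whether iodo itself brings this strength, or whether bromo, a methyl group or plain hydrogen on the same carbon would read alike. Also open, going by these compounds, is how much the 2-acetamidoethyl group contributes once iodo is in place.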